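A few compounds are considered here, and "the series" means these few. Any claim that something is new, unique, unknown or untested is made for them only; others in the source may bear on it.

In an ADME assay on WI-38 cells (Homo sapiens) for inhibition, read by sulforhodamine B assay, with a stated time of 24 h (a lower number here means a stronger inhibitor, a higher number a weaker inhibitor), three compounds have been measured so far. Compound 1 `Cc1ccc(C(=O)/C=C/c2ccc(C(=O)O)cc2)o1` gives 32000 nM. Compound 3 `COc1ccc(C(=O)/C=C/c2ccc(C(=O)O)cc2)cc1[N+](=O)[O-]` gives 29000 nM, and these two values lie within the scatter of each other. For compound 2 `O=C(O)c1ccc(/C=C/C(=O)c2ccccc2)cc1`, the assay reports a limit and not a number, > 100000 nM.

The next compound changes compound 3 at one place. Compound 4 `COc1ccc(C(=O)/C=C/c2ccc(C(=O)O)cc2)cc1OC` carries methoxy in place of nitro on an aromatic carbon, ortho to a methoxy group and meta to a large group: methoxy in place of nitro on an aromatic carbon.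

For the measured compounds named here, no measured step covers this exchange. Going by the values given here, the only step available is an at least 3.1-fold higher number from compound 1 to compound 2 (0.49 log units; beyond the scatter), with phenyl in place of 5-methylfuran-2-yl on a carbonyl carbon. It bears on the new change only loosely, showing that a change on that side of the molecule can move the number beyond the scatter. The starting point therefore remains compound 3 at 29000 nM, with a modest upward allowance, and a result at the limit of > 100000 nM in this assay, at which 1 of the 3 values shown sits, cannot be ruled out. In this assay, the expected step is a 1.4-fold higher number from compound 3 to compound 4 (0.14 log units; within the scatter), which is no change beyond the scatter. For compound 4, the estimated value is 40000 nM, with an expected range of 15000 nM to 100000 nM.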

Compound 4, half-maximal inhibitory concentration: 67400 nM
The estimate for compound 4 lay 1.7-fold (0.23 log units) below the measured number, within the range that was stated.
By their numbers in this assay, from the lowest: compounds 3 and 1 (each within the scatter of the next); then compound 4. At a limit, above all of these: compound 2.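

In this assay, for the compounds shown here, the exchange of nitro for methoxy on this aromatic carbon, ortho to a methoxy group and meta to a large group, gives a 2.3-fold higher number from compound 3 to compound 4 (0.37 log units; beyond the scatter), the first measured step at this position. The earlier compounds shown here showed a move beyond the scatter only for the group on the carbonyl carbon, an at least 3.1-fold higher number from compound 1 to compound 2 (0.49 log units; beyond the scatter), whereas here the number moves beyond the scatter with a single group exchanged on the aromatic ring and the rest of compound 3 unchanged. The step is modest, and compound 4 still gives a number and not a limit, while the limit remains with compound 2: the limit of > 100000 nM in this assay, at which 1 of the 4 values shown sits.

With only nitro and methoxy compared at this position, the compounds shown cannot tell which part of the exchange carries the step, and they give no reason for it. Going by these compounds, whether an amine, a chlorine atom or a longer chain such as ethoxy on this carbon would give a number closer to that of compound 3 or to that of compound 4 stays open, as does whether the same exchange would give a similar step with another group on the carbonyl carbon.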